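Swapping bromo for methoxy on the shared core

The compounds below may be only part of what the source reports. "The series", "measured", "known", "first", "only" and "open" are said of these compounds alone.

In a functional assay on MCF7 cells (Homo sapiens) for antiproliferative activity, read by MTT assay, with a stated time of 48 h (a lower number here means a stronger inhibitor, a higher number a weaker inhibitor), compound 3 `COc1ccc(-c2nn(-c3ccccc3)cc2-c2nc3cc(Br)ccc3[nH]2)cc1` gives 1830 nM. Its close relative compound 2 `COc1ccc(-c2nn(-c3ccccc3)cc2-c2nc3cc(Cl)ccc3[nH]2)cc1` gives 1760 nM, and compound 1 `COc1ccc2[nH]c(-c3cn(-c4ccccc4)nc3-c3ccc(F)cc3)nc2c1` gives 970 nM. All three numbers lie within the usual scatter of one another, so compound 3 stands level with the other two and no ranking can be drawn.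

Compound 4 `COc1ccc(-c2nn(-c3ccccc3)cc2-c2nc3cc(OC)ccc3[nH]2)cc1` changes one place on compound 3: methoxy in place of bromo on an aromatic carbon, (methoxy in place of bromo on an aromatic carbon). Among the measured compounds shown here, the only measured step at this place is bromo in place of chloro, a 1.0-fold higher number from compound 2 to compound 3 (0.02 log units; within the scatter), and it stayed within the scatter. That step exchanges one halogen for another, so it offers only indirect guidance on methoxy. Compound 1 also carries a methoxy on the shared core, although it differs elsewhere too, and its 970 nM lies within the scatter of compound 3.

The expected step of a 1.3-fold lower number from compound 3 to compound 4 (0.12 log units; within the scatter) therefore stays within the scatter, with no clear direction. For compound 4 the estimate is 1400 nM, with an expected range from 600 nM to 3300 nM.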

Compound 4, half-maximal inhibitory concentration: 3130 nM
The estimate for compound 4 lay 2.2-fold (0.35 log units) below the measured number; low and high end bracket the measured number.
By their numbers in this assay, from the lowest: compounds 1, 2, 3 and 4 (each within the scatter of the next, the first and the last beyond it).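

In this assay methoxy in place of bromo at this place on the shared core gives a 1.7-fold higher number from compound 3 to compound 4 (0.23 log units; within the scatter) and methoxy in place of chloro gives a 1.8-fold higher number from compound 2 to compound 4 (0.25 log units; within the scatter) so these two exchanges show no readable change at this position. The one clear gap is a 3.2-fold higher number from compound 1 to compound 4 (0.51 log units; beyond the scatter) and it is a modest one that arises from methoxy in place of fluoro at a different place, since compound 1 and compound 4 both carry methoxy at this place on the shared core. No supporting measurement bears on why these numbers fall as they do.

As far as these compounds go, it remains open whether an amine or a carboxylic acid at this place would also leave the number unchanged. A longer chain such as ethoxy is equally untested by the compounds shown here.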